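Swapping the amine on the fluorinated hydrazone series

The source may report more compounds than this note shows. Statements on the series, on what has been measured and on what is new or still open speak of the compounds shown alone.

Compound 1 `CC1CCN(Cc2ccc3nc(NC(=O)N/N=C/c4cn(Cc5cccc(Cl)c5)c5ccccc45)sc3c2)CC1` gives 2810 nM in a functional assay on A549 cells (Homo sapiens) for cytotoxicity, read by MTT assay, with a stated time of 72 h; a higher number here means a weaker inhibitor, a lower number a stronger inhibitor
Compound 2 `CN(C)Cc1ccc2nc(NC(=O)N/N=C3\C(=O)Nc4ccc(F)cc43)sc2c1` gives 2310 nM
Compound 3 `CC1CCN(Cc2ccc3nc(NC(=O)N/N=C4\C(=O)Nc5ccc(F)cc54)sc3c2)CC1` gives 3010 nM

Compound 3 lies within the scatter of both other compounds in this assay and no order among the three can be read. Compound 4 `CCN(CC)Cc1ccc2nc(NC(=O)N/N=C3\C(=O)Nc4ccc(F)cc43)sc2c1` puts diethylamino in place of 4-methylpiperidin-1-yl on a saturated chain carbon bound to an aromatic carbon. For the measured compounds named here, one measured step bears on this change, the exchange of dimethylamino for 4-methylpiperidin-1-yl at the same place, which was a 1.3-fold higher number from compound 2 to compound 3 (0.11 log units; within the scatter) and so gives no sign of sensitivity to this amine. The estimated step is a 1.2-fold lower number from compound 3 to compound 4 (0.06 log units; within the scatter) and no shift beyond the scatter is expected. Compound 4 is therefore expected at about 2600 nM (1400 nM to 4800 nM).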

Compound 4, half-maximal inhibitory concentration: 2010 nM
Compound 4: middle estimate off by 1.3-fold (0.11 log units), on the high side; measured number inside the range.
By their numbers in this assay, from the lowest: compounds 4, 2, 1 and 3 (each within the scatter of the next).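

With diethylamino as a third amine on the saturated chain carbon bound to an aromatic carbon, this assay still separates none of them: the readings give a 1.5-fold lower number from compound 3 to compound 4 (0.18 log units; within the scatter) and a 1.1-fold lower number from compound 2 to compound 4 (0.06 log units; within the scatter). Neither the two open-chain amines nor diethylamino and the ring-bearing 4-methylpiperidin-1-yl can be told apart here. No measurement is available that would explain these readings. As far as these compounds go, whether morpholin-4-yl or a carboxylic acid at this place would shift the number beyond the scatter remains open, as does whether diethylamino would read alike on the core of compound 1.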